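The compounds below may be only part of what the source reports. "The series", "measured", "known", "first", "only" and "open" are said of these compounds alone.

Measured in an ADME assay on microsomes from liver (Homo sapiens) for metabolic stability, read by LC-MS, using NADPH, with a stated time of 45 min, tested at 3 uM; a higher number here means that the compound lasts longer, a lower number that the compound disappears faster:
- compound 1 `C1CCC(C(CC2CCCCN2)C2CC2)CC1`: 2.07 h
- compound 2 `C1CCC(CC(C2CCCC2)C2CCCC2)NC1`: 0.833 h

Compound 1 holds the higher of these two half-lives, and its gap to compound 2 lies beyond the usual scatter. The next compound to be tested is compound 3 `C1CCC(C(CC2CCCCN2)C2CCOCC2)CC1`. It carries oxan-4-yl in place of cyclopropyl on a saturated chain carbon bound to a saturated chain carbon and a saturated ring carbon. For the measured compounds named here, no measured pair isolates this change, so the data give only weak guidance. In this assay, the estimated step of a 1.2-fold higher number from compound 1 to compound 3 (0.08 log units; within the scatter) is slightly upward and stays within the scatter. Compound 3 is expected to give 2.5 h, with an estimated range from 1 h to 6 h.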

Compound 3, half-life: 1.4 h
Compound 3: the middle estimate sits 1.8-fold (0.25 log units) above what was measured; the measured number falls inside the stated range.
By their numbers in this assay, from the lowest: compounds 2, 3 and 1 (each within the scatter of the next, the first and the last beyond it).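

For the compounds shown here, this is the first pair that isolates a single change at this position: in this assay, oxan-4-yl in place of cyclopropyl on a saturated chain carbon bound to a saturated chain carbon and a saturated ring carbon gives a 1.5-fold lower number from compound 1 to compound 3 (0.17 log units; within the scatter) and stays within the scatter. The position therefore takes a six-membered ring with one oxygen, and the half-lives of the pair cannot be told apart. No measurement offered here explains this result.
As far as these compounds go, how an amine or a longer chain at this carbon would fare remains open, and one pair cannot show whether the swap behaves alike on other cores.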